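This account rests on a few compounds, and the source may have more. Where it says the series, first, only, none or still open, it means among the compounds named here.

Series notes. The shared core of compound 1 `COC1=C(OC)[C@H](O)[C@H](C/C=C(\C)CC/C=C(\C)C[C@@H]2C[C@@H](C)C(=O)O2)[C@@H](C)C1=O` carries a five-membered lactone on the saturated chain carbon bound to a double-bonded chain carbon. In a functional assay on PC-3 cells (Homo sapiens) for inhibition, read by sulforhodamine B assay, with a stated time of 48 h (a lower number here means a stronger inhibitor of growth, a higher number a weaker inhibitor of growth), compound 1 reaches only the limit > 30000 nM. Among the compounds with values here, compound 2 `COC1=C(OC)[C@H](O)[C@H](C/C=C(\C)CC/C=C(\C)CCC=C(C)C)[C@@H](C)C1=O` carries the 3-methylbut-2-en-1-yl chain at that place, and in this assay compound 2 gives 13500 nM, the only number in the set. The two remaining values are limits (the limit of > 30000 nM in this assay, at which 2 of the 3 values shown sit). Within the data shown here, the single measured step is an at least 2.2-fold lower number from compound 1 to compound 2 (0.34 log units; beyond the scatter). Compound 3 `COC1=CC(=O)C(C/C=C(\C)CC/C=C(\C)CCC=C(C)C)=C(C)C1=O` has a different core. In this assay compound 3 also sits at the limit > 30000 nM.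

Compound 4 `COC1=C(OC)[C@H](O)[C@H](C/C=C(\C)CC/C=C(\C)C/C=C/C(C)(C)O)[C@@H](C)C1=O` is not yet measured. Its change from compound 2 is 3-hydroxy-3-methylbut-1-en-1-yl in place of 3-methylbut-2-en-1-yl on a saturated chain carbon bound to a double-bonded chain carbon. Among the measured compounds shown here, no measured step bears on such a change: the one step known concerns the lactone against the open chain, not the chain end, so it cannot be carried over. With nothing to argue a move in either direction, the expectation is that compound 4 lands near the weak growth inhibition of the series. The expected step is a 1.1-fold higher number from compound 2 to compound 4 (0.05 log units; within the scatter), within the scatter. Compound 4 is estimated at 15000 nM, range 5000 nM to 45000 nM, with a real chance that only a limit is returned.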

Compound 4, concentration for 50% growth inhibition: > 30000 nM
Compound 4 gave a limit, no number; the forecaster's own chance of this, stated with the estimate: 35%; middle value at least 2.0-fold (0.30 log units) away from the limit.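

In this assay, the step of an at least 2.2-fold higher number from compound 2 to compound 4 (0.34 log units; beyond the scatter) shows that growth inhibition at this place depends on the chain end itself as well as on the lactone seen earlier: even with the ring gone, 3-hydroxy-3-methylbut-1-en-1-yl does not match 3-methylbut-2-en-1-yl. The reading for compound 4 is a limit and not a number, so this step has a lower bound only, and the steps that join two limits cannot be read. Among the open-chain and lactone variants on the shared core, the 3-methylbut-2-en-1-yl chain of compound 2 is the only one that gives a number, and the series now rests mostly on limits: the limit of > 30000 nM in this assay, at which 3 of the 4 values shown sit.

The change from compound 2 to compound 4 alters both the hydroxyl and the place of the double bond in the chain end, so the compounds shown do not separate the two. Also open, as far as these compounds go, is how this assay responds at the same place to a saturated 3-methylbutyl end, a longer chain, an amine or a carboxylic acid.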